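The source may hold more compounds than are shown below. What is called first, only, known or untested is meant among the compounds shown, and "the series" means these compounds.

Measured in an assay on isolated protein for displacement of a labelled ligand from metabotropic glutamate receptor 5 (Homo sapiens), with a stated time of 60 min, tested at 1 uM; a higher number here means more inhibition at the concentration tested (going by the name of the read-out), a lower number less inhibition:
- compound 1 `COc1cccc(S(=O)(=O)c2cnc3ccc(F)cc3c2N2CCC(C)CC2)c1`: 90%
- compound 2 `CC1CCN(c2c(S(=O)(=O)c3ccc(C#N)cc3)cnc3ccc(F)cc23)CC1`: 75%

Compound 2 stands lowest of the two numbers in this assay; the nearest is compound 1, the step being a number 15 percentage points lower from compound 1 to compound 2 (beyond the scatter). Compound 3 `Cc1ccc(S(=O)(=O)c2cnc3ccc(F)cc3c2N2CCC(C)CC2)cc1Cl` differs from compound 2 by 3-chloro-4-methylphenyl in place of 4-cyanophenyl on a sulfonyl sulfur. Among the measured compounds shown here, the only step that bears on this change is the one on the sulfonyl sulfur, which was modest. Since the 4-cyanophenyl that gave the lower number leaves, compound 3 is expected to move by a number 10 percentage points higher from compound 2 to compound 3 (within the scatter), back toward the level of compound 1. Estimate for compound 3: 85%, range 65% to 98%.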

Compound 3, a percentage reported as inhibition, at one concentration (the size of the read-out at that concentration, not a potency): 91%
Beside the measured number, compound 3's estimate is 6 percentage points below it; the measured number falls inside the stated range.
By their numbers in this assay, from the lowest: compound 2; then compounds 1 and 3 (each within the scatter of the next).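

On the sulfonyl sulfur in this assay, replacing 4-cyanophenyl restores the number (a number 16 percentage points higher from compound 2 to compound 3 (beyond the scatter)), so the drop seen with compound 2 is not shared by every substituted phenyl group. The 3-chloro-4-methylphenyl and 3-methoxyphenyl groups cannot be told apart here (a number 1 percentage points higher from compound 1 to compound 3 (within the scatter)), and among the three compounds only compound 2 stands apart.

On these data alone, whether a carboxylic acid, an amine or a longer alkyl chain on the sulfonyl sulfur would keep the number remains open. No evidence on hand accounts for these steps.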